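The source may report more compounds than this note shows. Statements on the series, on what has been measured and on what is new or still open speak of the compounds shown alone.

Compound 1 `CNC(=O)c1cc(C(=O)NC2CC2)cn(CC2CCCOC2)c1=O`: in a physicochemical assay for solubility (a higher number here means a more soluble compound, a lower number a less soluble compound), compound 1 sits at >= 131 ug/mL, which is a limit of the assay and not a number.
Compound 2 `CNC(=O)c1cc(C(=O)NC2CC2)cn(CC2CCOCC2)c1=O`: in this assay compound 2 sits at >= 165 ug/mL, again a limit and not a number.
Compound 3 `CNC(=O)c1cc(C(=O)NC2CC2)cn(Cc2cccc3[nH]ccc23)c1=O`: in this assay compound 3 gives 78 ug/mL.

Among the compounds with values here, compound 3 thus holds the only true number among the three; the other two values are limits. The steps that lead to it both fall: an at least 1.6-fold lower number from compound 1 to compound 3 (0.22 log units; that floor lies within the scatter), and an at least 2.1-fold lower number from compound 2 to compound 3 (0.32 log units; beyond the scatter). The step from compound 1 to compound 2 cannot be read, as the limit of >= 131 ug/mL in this assay, at which 1 of the 3 values shown sits, and the limit of >= 165 ug/mL in this assay, at which 1 of the 3 values shown sits, are both limits.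

Compound 4 `CNC(=O)c1cc(C(=O)NC2CC2)cn(Cc2nccc3[nH]ccc23)c1=O` differs from compound 3 in one place: a group of 9 heavy atoms (7 carbon, 2 nitrogen; one five-membered aromatic ring with 1 hetero atom, one six-membered aromatic ring with 1 hetero atom) in place of a group of 9 heavy atoms (8 carbon, 1 nitrogen; one five-membered aromatic ring with 1 hetero atom, one six-membered aromatic ring of carbon only), on a saturated chain carbon bound to an aromatic nitrogen. Within the data shown here, none of the measured steps exchanges one ring pair for another of this kind, so no step bears directly on it; the two that reach compound 3 only show that the indol-4-yl compound lies below both oxanyl compounds. Among the measured compounds shown here, with no direct precedent, the expectation for compound 4 in this assay is a step of a 1.4-fold higher number from compound 3 to compound 4 (0.15 log units; within the scatter), upward but within the scatter. Compound 4 is therefore estimated at 110 ug/mL, with a range from 45 ug/mL to 260 ug/mL.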

Compound 4, solubility: 73 ug/mL
Estimate against measurement, compound 4: 1.5-fold (0.18 log units) above, and the stated range covers the measured number.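

In this assay, exchanging 1H-indol-4-yl for the group of 7 carbon and 2 nitrogen atoms, which carries a hydrogen-bond acceptor that 1H-indol-4-yl lacks, gives a 1.1-fold lower number from compound 3 to compound 4 (0.03 log units; within the scatter) and so leaves the two compounds indistinguishable at this position on the saturated chain carbon. Set against the oxanyl compounds, the new group gives an at least 2.2-fold lower number from compound 2 to compound 4 (0.35 log units; beyond the scatter) and also an at least 1.7-fold lower number from compound 1 to compound 4 (0.25 log units; that floor lies within the scatter) but these two steps each start from a limit of the assay and not a number, so only their floors can be read, and just the first floor clears the scatter. No measurement shown here accounts for the near-identical readings of compound 3 and compound 4.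

As far as these compounds go, the limits of compound 1 and compound 2 leave their true values unknown, so how far either lies from compound 4 stays open, and the step between those two cannot be read. Also open, from the compounds shown here alone, is how this assay would respond to a single-ring group such as phenyl or pyridinyl, or to a piperidine or a carboxylic acid, on the same chain carbon.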